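A few compounds are considered here, and "the series" means these few. Any claim that something is new, unique, unknown or untested is made for them only; others in the source may bear on it.

Measured compounds in a functional assay for antagonist activity at Neuropeptide Y receptor type 2 (Homo sapiens); a lower number here means a stronger inhibitor, a higher number a weaker inhibitor:
Compound 1 `COc1ccc(OC(=O)N2CCC(C(O)(c3ccccc3)c3ccccc3)CC2)cc1` gives 2680 nM.
Compound 2 `O=C(Oc1ccc(S(=O)(=O)N2CCCC2)cc1)N1CCC(C(O)(c2ccccc2)c2ccccc2)CC1` gives 49 nM.
Compound 3 `CCS(=O)(=O)c1ccc(OC(=O)N2CCC(C(O)(c3ccccc3)c3ccccc3)CC2)cc1` gives 59 nM.

Among these three, compound 3 gives the second highest number; its nearest neighbour is compound 2, with a 1.2-fold higher number from compound 2 to compound 3 (0.08 log units; within the scatter), and the furthest is compound 1, with a 45-fold lower number from compound 1 to compound 3 (1.66 log units; beyond the scatter). Compound 4 `CCN(CC)C(=O)c1ccc(OC(=O)N2CCC(C(O)(c3ccccc3)c3ccccc3)CC2)cc1` differs from compound 3 in one place: diethylcarbamoyl in place of ethylsulfonyl on an aromatic carbon. The measured steps that bear on this position are a 55-fold lower number from compound 1 to compound 2 (1.74 log units; beyond the scatter) and a 45-fold lower number from compound 1 to compound 3 (1.66 log units; beyond the scatter), both large, while a 1.2-fold higher number from compound 2 to compound 3 (0.08 log units; within the scatter) shows that the two sulfonyl variants sit together. Among the measured compounds shown here, none of these steps involves a carbamoyl group, so no direct precedent exists. The change is expected to raise the number somewhat: a 3.4-fold higher number from compound 3 to compound 4 (0.53 log units; beyond the scatter). Compound 4 is therefore estimated at 200 nM, with a range from 50 nM to 1000 nM.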

Compound 4, half-maximal inhibitory concentration: 220 nM
Beside the measured number, compound 4's estimate is 1.1-fold (0.04 log units) below it, within the range that was stated.
By their numbers in this assay, from the lowest: compounds 2 and 3 (each within the scatter of the next); then compound 4; then compound 1.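

Replacing the sulfonyl groups with diethylcarbamoyl weakens inhibition at this position (a 3.7-fold higher number from compound 3 to compound 4 (0.57 log units; beyond the scatter); a 4.5-fold higher number from compound 2 to compound 4 (0.65 log units; beyond the scatter)). Even so, a sulfonyl group is not needed for a large gain over methoxy (a 12-fold lower number from compound 1 to compound 4 (1.09 log units; beyond the scatter)), which places compound 4 between the two sulfonyl compounds and compound 1. No available evidence explains this ranking.

Still open, from the compounds shown here alone, is whether a dimethylcarbamoyl or pyrrolidin-1-ylcarbonyl group would match the sulfonyl compounds. How a carboxylic acid or a nitrile would rank on this aromatic carbon is also unknown.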